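Swapping cyclopentyl for 2-hydroxyethyl on the shared core

This account rests on a few compounds, and the source may have more. Where it says the series, first, only, none or still open, it means among the compounds named here.

Measured compounds:
- compound 1, `CCNc1nc(-c2ccccc2)nc2c1nnn2Cc1ccccc1Cl`: 463 nM
- compound 2, `CCCCCCNc1nc(-c2ccccc2)nc2c1nnn2Cc1ccccc1Cl`: 31 nM
- compound 3, `Clc1ccccc1Cn1nnc2c(NC3CCCC3)nc(-c3ccccc3)nc21`: 9 nM

All three were tested in an assay on Cerebral cortex for displacement of a labelled ligand from adenosine receptor A1 (Bos taurus); on this read-out higher numbers stand for weaker inhibition and lower numbers for stronger inhibition. Compound 3 gives the lowest number of the three; its nearest neighbour is compound 2, and the step of a 3.4-fold lower number from compound 2 to compound 3 (0.54 log units; beyond the scatter) shows how far apart they lie, while the step of a 51-fold lower number from compound 1 to compound 3 (1.71 log units; beyond the scatter) separates it from compound 1. Compound 4, `OCCNc1nc(-c2ccccc2)nc2c1nnn2Cc1ccccc1Cl`, has not yet been measured. It differs from compound 3 by a single change: 2-hydroxyethyl in place of cyclopentyl on a nitrogen on an aromatic ring. The two earlier steps ending at compound 3 bear on this: moving from the small ethyl chain of compound 1 to cyclopentyl gave a 51-fold lower number from compound 1 to compound 3 (1.71 log units; beyond the scatter), and from hexyl to cyclopentyl a 3.4-fold lower number from compound 2 to compound 3 (0.54 log units; beyond the scatter), so a short open chain in this position has so far gone with weaker binding than cyclopentyl. For the measured compounds named here, no measured compound carries a hydroxyl here, so that part of the change is untested. The expected outcome is therefore a clear rise in the number, a 44-fold higher number from compound 3 to compound 4 (1.65 log units; beyond the scatter), and compound 4 is estimated at 400 nM, with a range from 100 nM to 2000 nM.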

Compound 4, inhibition constant: 116 nM
Compound 4: the middle estimate sits 3.4-fold (0.54 log units) above what was measured, within the range that was stated.
By their numbers in this assay, from the lowest: compound 3; then compound 2; then compound 4; then compound 1.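

In this assay putting hydroxy on the ethyl chain gives a 4.0-fold lower number from compound 1 to compound 4 (0.60 log units; beyond the scatter) and so shows that, on this short chain, the added hydroxyl goes with stronger binding rather than weaker. That gain does not reach the long open chain, since replacing the butyl part of hexyl with hydroxy gives a 3.7-fold higher number from compound 2 to compound 4 (0.57 log units; beyond the scatter) and places 2-hydroxyethyl between ethyl and hexyl. Cyclopentyl remains the best of the four groups on this nitrogen, and replacing it with 2-hydroxyethyl gives a 13-fold higher number from compound 3 to compound 4 (1.11 log units; beyond the scatter) on the same read-out.

No supporting measurement is available to explain the gain from the hydroxyl. A 2-methoxyethyl or 2-aminoethyl chain would test whether the gain needs the hydroxyl itself, and a hydroxyl carried on the cyclopentyl ring would test whether it adds to what that ring gives.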